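Aryl to Benzyl Swap on the Amine of Compound 2

The compounds below may be only part of what the source reports. "The series", "measured", "known", "first", "only" and "open" are said of these compounds alone.

Of the compounds shown here, two of one shared core have so far been tested for growth inhibition in a functional assay on A549 cells (Homo sapiens) for antiproliferative activity, read by MTT assay, with a stated time of 48 h; on this read-out lower numbers stand for stronger inhibition and higher numbers for weaker inhibition. Compound 1 `CCOC(=O)CN(Cc1ccccc1)c1nc(NCc2ccccc2)ncc1[N+](=O)[O-]`, which carries benzyl groups and an ethyl ester, gives in this assay only > 100000 nM, a limit of the assay rather than a number. Within the data shown here, compound 2 `COC(=O)CN(C)c1nc(Nc2ccc(Cl)cc2)ncc1[N+](=O)[O-]`, which carries a methyl and a 4-chlorophenyl, gives in this assay 23500 nM, the only actual number so far. Compound 3 `COC(=O)CN(C)c1nc(NCc2ccccc2)ncc1[N+](=O)[O-]` differs from compound 2 in one place: benzyl in place of 4-chlorophenyl on a nitrogen on an aromatic ring. Among the measured compounds shown here, compound 1 already holds a benzylamino group, but it differs from compound 2 in more than one place, so no measured step isolates this change. The expected change is a 2.6-fold higher number from compound 2 to compound 3 (0.41 log units; beyond the scatter), with a fair chance that only a limit is reported. Compound 3 is therefore estimated at 60000 nM, between 20000 nM and 150000 nM.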

Compound 3, half-maximal inhibitory concentration: 79400 nM
Compound 3: middle estimate off by 1.3-fold (0.12 log units), on the low side; measured number inside the range.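

Among these compounds, until now, no pair of compounds isolated a change at this position; compound 2 and compound 3 differ only in the group on a nitrogen on an aromatic ring. In this assay, benzyl in place of 4-chlorophenyl gives a 3.4-fold higher number from compound 2 to compound 3 (0.53 log units; beyond the scatter), so this swap weakens growth inhibition by a modest step that is larger than the usual scatter. Both groups hold one six-membered aromatic ring of carbon only, so the step comes with a change that keeps that ring, although this single pair cannot separate the loss of chlorine from the gain of carbon.

As far as these compounds go, whether plain phenyl would sit nearer compound 2 or compound 3 stays open, as does the effect of a carboxylic acid in place of the methyl ester. Further weakening from compound 3 could soon reach a limit of the assay rather than a number: the limit of > 100000 nM in this assay, at which 1 of the 3 values shown sits.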